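A few compounds are considered here, and "the series" means these few. Any claim that something is new, unique, unknown or untested is made for them only; others in the source may bear on it.

Compound 2 `COc1cccc(-c2noc([C@H]3CCCN(C(=O)C4CCC4)C3)n2)c1` gives the lower of the two numbers measured in an in vitro functional assay on HEK293-A cells for negative allosteric modulation of metabotropic glutamate receptor 5 (Homo sapiens), read by fluorescence and calcium flux, with a stated time of 140 s (on this read-out lower numbers stand for stronger inhibition and higher numbers for weaker inhibition), at 1800 nM; compound 1 `O=C(C1CCC1)N1CCC[C@H](c2nc(-c3cccs3)no2)C1` gives 9300 nM, and the step of a 5.2-fold lower number from compound 1 to compound 2 (0.71 log units; beyond the scatter) separates them. Compound 3 `COc1cccc(-c2noc([C@@H]3CCCN(C(=O)C4CCC4)C3)n2)c1` keeps every atom and bond of compound 2 and differs only in configuration: the two compounds have the same atoms and bonds and differ only in configuration as drawn: 1 of 1 stereo elements differ; a stereocentre at a saturated ring carbon is drawn S in compound 2 and R in compound 3. Among the measured compounds shown here, none of the measured steps involves a change of configuration, so no step bears on this one, and the size and direction of the change are unknown from the data. Compound 3 is therefore expected at roughly 4000 nM, within 500 nM to 30000 nM, which would mean an estimated step of a 2.2-fold higher number from compound 2 to compound 3 (0.35 log units; beyond the scatter).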

Compound 3, half-maximal inhibitory concentration: > 10000 nM
Compound 3: a limit, no number; the forecaster's own chance of this, stated with the estimate: 25%; at least 2.5-fold (0.39 log units) between middle value and limit.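

Configuration at this saturated ring carbon matters, which the earlier compounds could not show: going from S to R gives an at least 5.5-fold higher number from compound 2 to compound 3 (0.74 log units; beyond the scatter) in this assay, and nothing else changes: the fact that compounds 2 and 3 differ only in the configuration as drawn. The reading for compound 3 is a limit of the assay and not a number, so the step has a minimum size but no known full size: the limit of > 10000 nM in this assay, at which 1 of the 3 values shown sits. The compounds shown leave open whether S is also the better drawing with the thiophen-2-yl of compound 1, or with a nitrile or a carboxylic acid in place of 3-methoxyphenyl.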